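From pyridin-4-yl to 1,2-thiazol-3-yl: an expected value

The compounds below may be only part of what the source reports. "The series", "measured", "known", "first", "only" and "open" are said of these compounds alone.

Compound 2 `COc1ccc(OC)c(Sc2ccc3nnc(-c4ccncc4)n3n2)c1` gives the highest of the three measured numbers in an assay on isolated protein for inhibition of Leucine-rich repeat serine/threonine-protein kinase 2 (Homo sapiens), in the presence of a further agent that is not named here (a lower number here means a stronger inhibitor, a higher number a weaker inhibitor), namely 349 nM. Compound 1 `COc1ccc(OC)c(Sc2ccc3nnc(-c4cccnc4)n3n2)c1` gives 242 nM, and a 1.4-fold higher number from compound 1 to compound 2 (0.16 log units; within the scatter) lies within the scatter. Among the measured compounds shown here, compound 3 `COc1cncc(-c2nnc3ccc(Sc4cc(OC)ccc4OC)nn23)c1` gives 66 nM; a 5.3-fold lower number from compound 2 to compound 3 (0.72 log units; beyond the scatter) is the only clear step among the three. Compound 4 `COc1ccc(OC)c(Sc2ccc3nnc(-c4ccsn4)n3n2)c1` carries 1,2-thiazol-3-yl in place of pyridin-4-yl on an aromatic carbon. For the measured compounds named here, no measured step exchanges a six-membered ring for a five-membered one; the pyridin-3-yl to pyridin-4-yl exchange changed little, and the improvement seen in compound 3 arrived together with a methoxy that compound 4 does not carry. A step of a 1.2-fold lower number from compound 2 to compound 4 (0.07 log units; within the scatter) is therefore expected, with nothing clearly beyond the scatter. Compound 4 is estimated at 300 nM, between 100 nM and 900 nM.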

Compound 4, half-maximal inhibitory concentration: 91 nM
For compound 4 the middle estimate is 3.3-fold (0.52 log units) above the measured one, outside the stated range (below it).
By their numbers in this assay, from the lowest: compounds 3 and 4 (each within the scatter of the next); then compounds 1 and 2 (each within the scatter of the next).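

In this assay, the five-membered 1,2-thiazol-3-yl at this position gives a modest gain, beyond the scatter, over both pyridines (a 3.8-fold lower number from compound 2 to compound 4 (0.58 log units; beyond the scatter); a 2.7-fold lower number from compound 1 to compound 4 (0.42 log units; beyond the scatter)). Compound 4 also stands within the scatter of compound 3 (a 1.4-fold higher number from compound 3 to compound 4 (0.14 log units; within the scatter)), without the 5-methoxypyridin-3-yl group. Nothing available explains the gain.

As far as these compounds go, whether it follows ring size, the sulfur or the second ring hetero atom remains open. Also open, from the compounds shown here alone, is whether a methoxy, an amine or a carboxylic acid on the 1,2-thiazol-3-yl ring would add to it.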